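The compounds below may be only part of what the source reports. "The series", "measured", "known", "first", "only" and "open" are said of these compounds alone.

Compound 1, `O=S(=O)(Nc1ccc2oc(-c3ccccc3)nc2c1)c1ccccc1C(F)(F)F`, gives > 63000 nM in an assay on isolated protein for inhibition of malate dehydrogenase, mitochondrial (Sus scrofa), with stated times of 45 min and 30 min; on this read-out lower numbers stand for stronger inhibition and higher numbers for weaker inhibition.
Compound 2, `O=S(=O)(Nc1ccc(-c2nc3ccccc3o2)cc1)c1cccc(C(F)(F)F)c1`, gives > 63000 nM in this assay.
Compound 3, `O=S(=O)(Nc1ccc(-c2nc3ccccc3o2)cc1)c1ccccc1F`, gives > 63000 nM in this assay.

None of these three numbers is a measured concentration: each is a limit of this assay, the point beyond which it reports nothing more. Compound 1 therefore stands at the limit, and so do compound 2 and compound 3; the limit of > 63000 nM in this assay, at which 3 of the 3 values shown sit, shows that every value in hand sits at this one limit. Going by the values given here, no step between two measured compounds can be drawn from such values, and nothing separates the three from one another.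

Compound 4, `O=S(=O)(Nc1ccc2oc(-c3ccccc3)nc2c1)c1ccccc1F`, has not yet been measured in this assay. It differs from compound 1 in one place: fluoro in place of trifluoromethyl on an aromatic carbon. Compound 3 already carries fluoro on its sulfonyl ring and still sits at the limit, so the account expects no step beyond the scatter; the step from compound 1 to compound 4 is estimated as a step that the limit leaves unreadable from compound 1 to compound 4. Compound 4 is expected at 100000 nM, within 40000 nM to 300000 nM, most likely again reported only as a limit.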

Compound 4, half-maximal inhibitory concentration: > 63000 nM
Compound 4: no number, only a limit; the forecaster's own chance of this, stated with the estimate: 85%; the middle value lies beyond the limit too.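

Compound 4 gives > 63000 nM in this assay, and this is a limit. Going by these compounds alone, no step from compound 1 to compound 4 can be read from it. The compounds shown leave open what change, if any, would bring a measured number in this assay: the limit of > 63000 nM in this assay, at which 4 of the 4 values shown sit.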